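Propargylamine in place of isopropylamine on a benzyl-substituted indole core

The source may report more compounds than this note shows. Statements on the series, on what has been measured and on what is new or still open speak of the compounds shown alone.

Measured compounds:
- compound 1, `CC(C)NCc1cn(Cc2ccccc2)c2ccccc12`: 132000 nM
- compound 2, `C#CCNCc1cc2ccccc2n1C`: 240 nM
- compound 3, `C#CCN(C)Cc1cc2cc(O)ccc2n1C`: 3.98 nM

In an assay on isolated protein for inhibition of Amine oxidase [flavin-containing] A (Rattus norvegicus) (on this read-out higher numbers stand for weaker inhibition and lower numbers for stronger inhibition), compound 1 gives 132000 nM, the highest of the three numbers and therefore the weakest inhibition shown. Going by the values given here, compound 2 gives 240 nM and compound 3 gives 3.98 nM; both carry a propargyl group on the amine and sit on a different core, so no single step connects them to compound 1, and their numbers show only that propargyl-bearing amines here reach far lower values.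

Compound 4, `C#CCN(C)Cc1cn(Cc2ccccc2)c2ccccc12`, has not been measured. It differs from compound 1 in one place: methyl(propargyl)amino in place of isopropylamino on a saturated chain carbon bound to an aromatic carbon. Among the compounds with values here, since no measured pair isolates this change on the core of compound 1, the expectation rests on the values of compound 2 and compound 3 alone. A large step downward, well beyond the scatter, is expected from compound 1 to compound 4, estimated at a 220-fold lower number from compound 1 to compound 4 (2.34 log units; beyond the scatter). Compound 4 is accordingly expected to give about 600 nM, within a range of 30 nM to 12000 nM.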

Compound 4, inhibition constant: 158000 nM
Beside the measured number, compound 4's estimate is 260-fold (2.42 log units) below it; the measured number lies above the stated range.
By their numbers in this assay, from the lowest: compound 3; then compound 2; then compounds 1 and 4 (each within the scatter of the next).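

In this assay methyl(propargyl)amino in place of isopropylamino on a saturated chain carbon bound to an aromatic carbon gives a 1.2-fold higher number from compound 1 to compound 4 (0.08 log units; within the scatter) and so leaves the number on the core of compound 1 unchanged within the scatter. Compound 2 and compound 3 sit on a different core and could not show that, on the core of compound 1, this propargyl-bearing amine brings no lower number. Nothing shown accounts for this result.

Left open is how the same amine behaves on this core when the benzyl group gives way to an ethyl group, or when a hydroxyl group is added to the core. Also open, as far as these compounds go, is whether a primary amine on the same chain carbon would read any differently from isopropylamino and methyl(propargyl)amino.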